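A few compounds are considered here, and "the series" means these few. Any claim that something is new, unique, unknown or untested is made for them only; others in the source may bear on it.

Compound 1 `CN1CCN(c2ccc(Nc3ncc4nc(Nc5ccc(F)cc5)n([C@@H]5CCN(C(=O)CO)C5)c4n3)cc2)CC1` gives 350 nM in a functional assay on HCC827 cells (Homo sapiens) for antiproliferative activity, read by MTT assay, with a stated time of 72 h; on this read-out lower numbers stand for stronger inhibition and higher numbers for weaker inhibition; compound 2 `CN1CCN(c2ccc(Nc3ncc4nc(Nc5ccc(F)cc5)n([C@H]5CCNC5)c4n3)cc2)CC1` gives 1220 nM; compound 3 `CN1CCN(c2ccc(Nc3ncc4nc(Nc5ccc(F)cc5)n([C@@H]5CCN(S(=O)(=O)C6CC6)C5)c4n3)cc2)CC1` gives 2.5 nM.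

Compound 3 has the lowest number of the three, below compound 1 by a 140-fold lower number from compound 1 to compound 3 (2.15 log units; beyond the scatter) and below compound 2 by a 490-fold lower number from compound 2 to compound 3 (2.69 log units; beyond the scatter). Compound 4 `CN1CCN(c2ccc(Nc3ncc4nc(Nc5ccc(F)cc5)n([C@H]5CCN(C(=O)OC(C)(C)C)C5)c4n3)cc2)CC1` differs from compound 3 by 1-(tert-butoxycarbonyl)pyrrolidin-3-yl in place of 1-(cyclopropylsulfonyl)pyrrolidin-3-yl on an aromatic nitrogen. Among the compounds with values here, the steps that bear on this are the two that arrive at the cyclopropylsulfonyl group, a 140-fold lower number from compound 1 to compound 3 (2.15 log units; beyond the scatter) and a 490-fold lower number from compound 2 to compound 3 (2.69 log units; beyond the scatter), both large. Since the tert-butoxycarbonyl group is a carbonyl substituent like that of compound 1, which gave 350 nM, a large step upward in this assay is expected, of about an 80-fold higher number from compound 3 to compound 4 (1.90 log units; beyond the scatter). Compound 4 is therefore estimated at 200 nM, within 40 nM to 1000 nM.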

Compound 4, half-maximal inhibitory concentration: 580 nM
Compound 4: the middle estimate sits 2.9-fold (0.46 log units) below what was measured, within the range that was stated.
By their numbers in this assay, from the lowest: compound 3; then compounds 1 and 4 (each within the scatter of the next); then compound 2.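

On the ring amine nitrogen in this assay, tert-butoxycarbonyl gains only modestly over the free amine (a 2.1-fold lower number from compound 2 to compound 4 (0.32 log units; beyond the scatter)). It also sits with the (hydroxymethyl)carbonyl group (a 1.7-fold higher number from compound 1 to compound 4 (0.22 log units; within the scatter)), so the two carbonyl groups shown fall together despite their different sizes. Cyclopropylsulfonyl stands well apart from both (a 230-fold higher number from compound 3 to compound 4 (2.37 log units; beyond the scatter)), so among these compounds the low number belongs to the sulfonyl compound alone. Nothing here explains that gap. Going by these compounds, whether methylsulfonyl or phenylsulfonyl would keep the low number, or a cyclopropylcarbonyl group would share it, stays open.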